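The compounds below may be only part of what the source reports. "The series", "measured", "known", "first", "only" and "open" are said of these compounds alone.

Compound 1, `CC1(C)[C@H]2CC[C@]1(C)N(Cc1cn(-c3ccc(C#N)cc3)nn1)C(=O)C2`, gives 500 nM in a functional assay on SGC-7901 cells (Homo sapiens) for inhibition, read by MTT assay, with a stated time of 24 h; on this read-out higher numbers stand for weaker inhibition and lower numbers for stronger inhibition.
Compound 2, `CC1(C)[C@H]2CC[C@]1(C)N(Cc1cn(-c3ccc(F)cc3)nn1)C(=O)C2`, gives 500 nM.
Compound 3, `CC1(C)[C@H]2CC[C@]1(C)N(Cc1cn(-c3ccccc3)nn1)C(=O)C2`, gives 240 nM.

On these three numbers compound 2 stands level with compound 1 at the digits shown, and the two together are the highest of the set. Compound 3 lies lower: a 2.1-fold lower number from compound 2 to compound 3 (0.32 log units; beyond the scatter), and likewise a 2.1-fold lower number from compound 1 to compound 3 (0.32 log units; beyond the scatter). Between the two substituted compounds there is nothing to separate: no change at the digits printed from compound 1 to compound 2 (within the scatter).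

Compound 4, `COc1ccc(-n2cc(CN3C(=O)C[C@@H]4CC[C@@]3(C)C4(C)C)nn2)cc1`, differs from compound 2 in one place: methoxy in place of fluoro on an aromatic carbon.

Two kinds of step bear on this change. Exchanging one group for another on that aromatic carbon, as from compound 1 to compound 2, left the number where it was. Removing the group altogether, as from compound 2 to compound 3, brought a modest lowering. Among the compounds with values here, compound 4 keeps a group at that carbon rather than removing it, so the first kind of step is the closer precedent, and no methoxy analogue has been measured to say otherwise. The expectation is therefore for no step beyond the scatter: no change at the digits printed from compound 2 to compound 4 (within the scatter).

Compound 4 is estimated at 500 nM, within a range of 200 nM to 1200 nM.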

Compound 4, half-maximal inhibitory concentration: 480 nM
Beside the measured number, compound 4's estimate is 1.0-fold (0.02 log units) above it; measured number inside the range.
By their numbers in this assay, from the lowest: compounds 3, 4, 1 and 2 (each within the scatter of the next, the first and the last beyond it).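

With methoxy, three different groups para to a large group now give numbers that cannot be told apart in this assay: the step to methoxy reads a 1.0-fold lower number from compound 2 to compound 4 (0.02 log units; within the scatter) and, from the nitrile, a 1.0-fold lower number from compound 1 to compound 4 (0.02 log units; within the scatter) on the same scale. The hydrogen compound is less clearly set apart than before, since a 2.0-fold higher number from compound 3 to compound 4 (0.30 log units; within the scatter) stays inside the scatter, while the steps to compound 3 from the fluoro and nitrile compounds lay just beyond it, so compound 4 goes against any clean division between compound 3 and the substituted compounds. Nothing among the data offered here accounts for this flat response at that carbon.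

What the compounds shown leave open is whether this flatness holds for groups of other kinds on the same carbon, such as an amine, a carboxylic acid or a longer chain like butoxy, or whether one of these would move the number clearly away from the level of compounds 1, 2 and 4. They also leave open whether the same groups would behave alike on another carbon of that ring, and whether the small gap to compound 3 would persist on repeated measurement.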